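The source may hold more compounds than are shown below. What is called first, only, known or untested is meant among the compounds shown, and "the series" means these compounds.

Measured in a functional assay on MCF7 cells (Homo sapiens) for antiproliferative activity, read by MTT assay, with a stated time of 24 h; on this read-out higher numbers stand for weaker inhibition and lower numbers for stronger inhibition:
- compound 1 `CCn1c(C(=O)N[C@@H](CO)C(C)C)ccc1C(CC)(CC)c1ccc(OCS(=O)(=O)c2ccccc2)c(C)c1`: 18800 nM
- compound 2 `CCn1c(C(=O)N[C@H](CO)CCCO)ccc1C(CC)(CC)c1ccc(OCS(=O)(=O)c2ccccc2)c(C)c1`: 31400 nM

Compound 2, at 31400 nM, cannot be ranked against compound 1, as the two values lie within the scatter of each other. Compound 3 `CCn1c(C(=O)NCC(=O)O)ccc1C(CC)(CC)c1ccc(OCS(=O)(=O)c2ccccc2)c(C)c1` keeps the shared core and changes only the group on the amide-type nitrogen: a group of 4 heavy atoms (2 carbon, 2 oxygen; no ring) in place of a group of 7 heavy atoms (5 carbon, 2 oxygen; no ring), on an amide-type nitrogen. A carboxymethyl group therefore takes the place of the larger group in compound 2.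

For the measured compounds named here, only one measured step bears on this change, and it alters the same place: a 1.7-fold higher number from compound 1 to compound 2 (0.22 log units; within the scatter). Going by the values given here, that step was small, but no measured compound carries carboxymethyl, so it offers only weak guidance. No step beyond the scatter is expected in this assay, and no direction can be favoured. The expected step is a 1.0-fold lower number from compound 2 to compound 3 (0.02 log units; within the scatter). For compound 3 the estimated value is 30000 nM, with an expected range from 12000 nM to 80000 nM.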

Compound 3, half-maximal inhibitory concentration: 33100 nM
Compound 3: middle estimate off by 1.1-fold (0.04 log units), on the low side; the measured number falls inside the stated range.
By their numbers in this assay, from the lowest: compounds 1, 2 and 3 (each within the scatter of the next).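

In this assay carboxymethyl, a group of 4 heavy atoms with no defined stereocentre, gives a step within the scatter whichever compound it is compared with (a 1.1-fold higher number from compound 2 to compound 3 (0.02 log units; within the scatter); a 1.8-fold higher number from compound 1 to compound 3 (0.25 log units; within the scatter)). For the compounds shown here, this extends the earlier picture: on an amide-type nitrogen, a change of group can be much larger than the one between compound 1 and compound 2 and still leave all three compounds unranked. Nothing available explains why the numbers stay so close.

As far as these compounds go, it remains open whether a group with an amine, a benzyl ring or a longer chain ending in a carboxylic acid on this nitrogen would give a step beyond the scatter in this assay. From the compounds shown here alone, the effect of changes elsewhere on the shared core also remains open.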